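Bromo on the Shared Core: An Expected Seizure Read-Out

The compounds below may be only part of what the source reports. "The series", "measured", "known", "first", "only" and "open" are said of these compounds alone.

Measured in a functional assay on the whole organism (strain albino) with Rattus norvegicus as the target, in the maximal electroshock model, with a stated time of 1 h, at a dose of 30 mg/kg by the intraperitoneal route; on this read-out higher numbers stand for more inhibition at the one dose given (going by the name of the read-out) and lower numbers for less inhibition:
compound 1, `Cc1nc2ccc(Br)cc2c(=O)n1NCc1nnc(/N=C/c2ccccc2)s1`: 50%
compound 2, `COc1cc(/C=N/c2nnc(CNn3c(C)nc4ccc(Br)cc4c3=O)s2)ccc1O`: 50%
compound 3, `Cc1nc2ccccc2c(=O)n1NCc1nnc(/N=C/c2ccc(O)cc2)s1`: 50%

Compound 3 stands level with compound 1 and compound 2 in this assay; all three values lie within the usual scatter of one another, so no order among them can be read from these numbers.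

The unmeasured compound 4, `Cc1nc2ccc(Br)cc2c(=O)n1NCc1nnc(/N=C/c2ccc(O)cc2)s1`, differs from compound 3 in a single place: bromo in place of hydrogen on an aromatic carbon. Going by the values given here, the only measured step in this set, no change at the digits printed from compound 1 to compound 2 (within the scatter), concerns a different part of the molecule, the phenyl group on the carbon with a double bond to nitrogen, and it produced no change. Among the compounds with values here, no measured pair differs by the bromo alone, so there is no direct comparison. What the data do show is that compound 1 and compound 2, which both carry bromo on the core, and compound 3, which does not, all give the same value within the scatter.

The step of no change at the digits printed from compound 3 to compound 4 (within the scatter) is therefore expected to be none beyond the scatter. For compound 4 the estimate is 50%, with a range from 30% to 70%.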

Compound 4, a percentage reported as inhibition, in the whole organism at one dose (the size of the read-out at that dose, not a potency): 50%
Estimate against measurement, compound 4: no gap at the digits printed, and the stated range covers the measured number.
By their numbers in this assay, from the lowest: compounds 1, 2, 3 and 4 (each within the scatter of the next).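

In this assay, bromo in place of hydrogen on an aromatic carbon of the shared core now has its first direct comparison, and the result is no change at the digits printed from compound 3 to compound 4 (within the scatter). The earlier step changed two things at once, since the 4-hydroxy-3-methoxyphenyl group brought in both a hydroxy and a methoxy, whereas the new compound lets each be read alone, giving no change at the digits printed from compound 1 to compound 4 (within the scatter) for the hydroxy and no change at the digits printed from compound 2 to compound 4 (within the scatter) for the removal of methoxy. None of these single changes, on the core or on the phenyl group, moves this read-out beyond the scatter, although a value at one dose is not a potency, so compounds that are level here could still part at other doses.

No measurement here offers an explanation for these flat results. On these data alone, it remains open whether a different group on this aromatic carbon, such as chloro, an amine or a carboxylic acid, would move the read-out away from the level shared by these four compounds.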